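This account rests on a few compounds, and the source may have more. Where it says the series, first, only, none or still open, it means among the compounds named here.

Working notes on the series. In a functional assay on MCF7 cells (Homo sapiens) for inhibition, read by MTT assay, with a stated time of 72 h (a lower number here means a stronger inhibitor, a higher number a weaker inhibitor), compound 1 (`C[C@H](NC(=O)c1cc(Cl)ccc1OCCNC(=O)OC(C)(C)C)C(=O)Nc1ccc([N+](=O)[O-])cc1Cl`) returns only a limit, > 10000 nM. As far as these compounds go, compound 2 (`C[C@H](NC(=O)c1cc(Cl)ccc1OCCN)C(=O)Nc1ccc([N+](=O)[O-])cc1Cl`) also returns only a limit, > 10000 nM, so its true standing is unknown. Together these values make up the whole record so far: the limit of > 10000 nM in this assay, at which 2 of the 2 values shown sit. Among the compounds with values here, the single measured step, a step that the two limits leave unreadable from compound 1 to compound 2, lies on an amine nitrogen and offers no size to carry over.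

Compound 3 (`CC(C)C[C@H](NC(=O)c1cc(Cl)ccc1OCCN)C(=O)Nc1ccc([N+](=O)[O-])cc1Cl`) differs by isopropyl in place of hydrogen on a saturated chain carbon, two bonds along the chain from an amide-type nitrogen and a carbonyl carbon, on a saturated chain carbon, two bonds along the chain from an amide-type nitrogen and a carbonyl carbon. Within the data shown here, no measured step covers this place, so no step beyond the scatter is expected in this assay, and a further limit reading is quite likely. The expected step is a number no higher from compound 2 to compound 3 (the limit leaves the size open). For compound 3 the estimated value is 10000 nM, with an expected range of 2500 nM to 30000 nM.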

Compound 3, half-maximal inhibitory concentration: > 10000 nM
Compound 3 ended at the assay's limit; the forecaster's own chance of this, stated with the estimate: 70%; the middle value sits exactly at the limit.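

Compound 2 and compound 3 both return only limits, so no step can be read between them. The compounds shown leave open the true standing of compound 1, compound 2 and compound 3, and whether isopropyl in place of hydrogen on that chain carbon shifts the read-out at all.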